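Varying the anilide ring on a pyridine-N-oxide piperidine

This account rests on a few compounds, and the source may have more. Where it says the series, first, only, none or still open, it means among the compounds named here.

In a functional assay on HEK293 cells for agonist activity at D(4) dopamine receptor (Homo sapiens), read by FLIPR (a lower number here means a smaller maximal response, a higher number a larger maximal response), compound 2 `Cc1cc(NC(=O)CN2CCC(c3cccc[n+]3[O-])CC2)ccc1F` gives 75% and compound 1 `O=C(CN1CCC(c2cccc[n+]2[O-])CC1)Nc1cccc(F)c1` gives 70%, so the two sit within the scatter of each other. For the measured compounds named here, the only measured step at this position, a number 5 percentage points higher from compound 1 to compound 2 (within the scatter), already describes swapping one aryl group for another on the amide-type nitrogen. Compound 3 `O=C(CN1CCC(c2cccc[n+]2[O-])CC1)Nc1ccc(F)cc1F` differs from compound 2 by 2,4-difluorophenyl in place of 4-fluoro-3-methylphenyl on an amide-type nitrogen. Because a number 5 percentage points higher from compound 1 to compound 2 (within the scatter) stayed within the scatter, no step beyond the scatter is expected for a number 3 percentage points lower from compound 2 to compound 3 (within the scatter). For compound 3 the expected value is therefore 72%, estimated between 55% and 86%.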

Compound 3, largest response reached (reported as efficacy), in percent of the reference or control that the assay uses: 74%
Beside the measured number, compound 3's estimate is 2 percentage points below it, and the stated range covers the measured number.
By their numbers in this assay, from the lowest: compounds 1, 3 and 2 (each within the scatter of the next).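

In this assay, the 2,4-difluorophenyl group on the amide-type nitrogen gives a number 1 percentage points lower from compound 2 to compound 3 (within the scatter) and a number 4 percentage points higher from compound 1 to compound 3 (within the scatter). All three fluorine-bearing phenyl groups shown therefore give responses within the scatter of one another, and the change to a second fluorine with no methyl group leaves the maximal response unshifted. Nothing available explains this flat result. Still open, as far as these compounds go, is whether a phenyl ring carrying an amine or a carboxylic acid, or a longer chain in place of the aryl group, would move the response beyond the scatter.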